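Methyl in Place of Hydrogen on the Anilino Ring

This account rests on a few compounds, and the source may have more. Where it says the series, first, only, none or still open, it means among the compounds named here.

compound 1, `CC(C)c1ccc(-c2nc(SCc3cn(CC(=O)NC(=O)Nc4ccccn4)nn3)nc(Nc3cccc(Cl)c3)c2C#N)cc1`: > 64000 nM
compound 2, `CC(C)c1ccc(-c2nc(SCc3cn(CC(=O)NC(=O)Nc4ccccn4)nn3)nc(Nc3ccccc3)c2C#N)cc1`: 15800 nM

Among the measured compounds shown here, in a functional assay on MGC-803 cells (Homo sapiens) for inhibition, read by MTT assay, with a stated time of 72 h (on this read-out lower numbers stand for stronger inhibition and higher numbers for weaker inhibition), compound 2 gives 15800 nM, the only proper number among the two results. For compound 1 the assay reports only a limit, > 64000 nM. For the measured compounds named here, the single measured step is therefore bounded on one side, as seen in an at least 4.0-fold lower number from compound 1 to compound 2 (0.60 log units; beyond the scatter), whose size follows from the limit of > 64000 nM in this assay, at which 1 of the 2 values shown sits.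

Compound 3, `Cc1ccccc1Nc1nc(SCc2cn(CC(=O)NC(=O)Nc3ccccn3)nn2)nc(-c2ccc(C(C)C)cc2)c1C#N`, differs from compound 2 by methyl in place of hydrogen on an aromatic carbon. Going by the values given here, no measured step concerns a methyl group, and the only step available concerns a chloro group at another place on the same ring; there, removing a substituent from that ring went with a lower number. On that basis compound 3 is expected to sit somewhat higher than compound 2, with a real chance of another limit. The expected step is a 2.0-fold higher number from compound 2 to compound 3 (0.31 log units; beyond the scatter). Compound 3 is estimated at 32000 nM, within a range of 12000 nM to 90000 nM.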

Compound 3, half-maximal inhibitory concentration: 19000 nM
Compound 3: the middle estimate sits 1.7-fold (0.23 log units) above what was measured; the range from low to high includes it.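

Methyl on an aromatic carbon ortho to a large group leaves the anilino ring's result in this assay within the scatter, with a 1.2-fold higher number from compound 2 to compound 3 (0.08 log units; within the scatter), so a substituent on this ring does not by itself go with the result seen for compound 1. Setting 2-methylphenyl in place of 3-chlorophenyl gives an at least 3.3-fold lower number from compound 1 to compound 3 (0.52 log units; beyond the scatter). Compound 1 stands at a limit, so only one side of that step is fixed: the limit of > 64000 nM in this assay, at which 1 of the 3 values shown sits.

Group and place change together between compound 1 and compound 3, which leaves open whether the kind of group or its place on the ring goes with the difference. Also open, from the compounds shown here alone, is how a methoxy group or an amine on the anilino ring would read in this assay, and how a chloro group would read at the carbon that carries methyl in compound 3.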